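Compound 3 to Compound 4: Tolerance Stays at the Limit

A few compounds are considered here, and "the series" means these few. Any claim that something is new, unique, unknown or untested is made for them only; others in the source may bear on it.

Compound 1 `CC(Sc1nnc(-c2ccncc2)s1)C(=O)Nc1ccccc1Cl`, compound 2 `CC(CSc1nnc(-c2ccncc2)s1)C(=O)Nc1ccc(Cl)cc1Cl` and compound 3 `O=C(CCSc1nnc(-c2ccncc2)s1)Nc1ccc(Cl)cc1Cl` were each examined in an ADME assay on BHK-21 cells (Mesocricetus auratus) for cytotoxicity, with a stated time of 3 days; a lower number here means that less compound is tolerated, a higher number that more compound is tolerated. In that assay compound 1 gives > 50000 nM, which is a limit of the assay rather than a number. Compound 2 likewise gives > 50000 nM, again a limit. Compound 3 gives > 50000 nM, also a limit. Within the data shown here, all three thus sit at the same limit (the limit of > 50000 nM in this assay, at which 3 of the 3 values shown sit), and the only step between neighbours, a step that the two limits leave unreadable from compound 2 to compound 3, cannot be read. Compound 4 `O=C(CCSc1nnc(-c2ccncc2)s1)NCc1ccc(Cl)cc1` differs from compound 3 by 4-chlorobenzyl in place of 2,4-dichlorophenyl on an amide-type nitrogen. Among the measured compounds shown here, no measured step bears on this change, so the expected step is a number no higher from compound 3 to compound 4 (the limit leaves the size open), meaning none beyond the scatter. Compound 4 is therefore estimated at 50000 nM, with a range from 20000 nM to 100000 nM.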

Compound 4, half-maximal cytotoxic concentration: 21500 nM
Compound 4: middle estimate off by 2.3-fold (0.37 log units), on the high side; the range from low to high includes it.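

In this assay, 4-chlorobenzyl in place of 2,4-dichlorophenyl on the amide-type nitrogen gives an at least 2.3-fold lower number from compound 3 to compound 4 (0.36 log units; beyond the scatter). This is the first change shown to give a readable drop in tolerance, and compound 4 is the first compound here with a number rather than a limit, so how large the step really is stays open on one side: the limit of > 50000 nM in this assay, at which 3 of the 4 values shown sit.

The change swaps the aromatic group and removes a chlorine together, so the compounds shown leave open which of the two goes with the lower number. They also leave open how an amine or a carboxylic acid on that ring would read in this assay.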